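Changing the pyridine ring on the benzyl-type arm

This account rests on a few compounds, and the source may have more. Where it says the series, first, only, none or still open, it means among the compounds named here.

Measured compounds:
- compound 1 `Nc1ncnc2c(C(=O)Nc3cccc4c3c(Br)nn4Cc3ccccc3)csc12`: 1010 nM
- compound 2 `Nc1ncnc2c(C(=O)Nc3cccc4c3c(Br)nn4Cc3ccncc3)csc12`: 135 nM

In a functional assay on NFS-60 cells (Mus musculus) for inhibition, with a stated time of 72 h (a lower number here means a stronger inhibitor of growth, a higher number a weaker inhibitor of growth), compound 2 has the lower of the two numbers at 135 nM, which makes it the stronger inhibitor of growth so far. Compound 3 `Nc1ncnc2c(C(=O)Nc3cccc4c3c(Br)nn4Cc3cccc(F)n3)csc12` keeps the shared core and differs from compound 2 in one place, on a saturated chain carbon bound to an aromatic nitrogen: 6-fluoropyridin-2-yl in place of pyridin-4-yl on a saturated chain carbon bound to an aromatic nitrogen.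

Among the compounds with values here, only one measured step bears on this place. Putting pyridin-4-yl in place of phenyl gave a 7.5-fold lower number from compound 1 to compound 2 (0.87 log units; beyond the scatter), so the group here can shift the number clearly. Within the data shown here, no measured compound carries a 6-fluoropyridin-2-yl group, however, so the data give only indirect guidance. With so little to go on, part of the gain seen in that step may be lost, and a move towards a higher number seems more likely than a further drop.

The expected change is a 1.9-fold higher number from compound 2 to compound 3 (0.27 log units; within the scatter), smaller than the measured step. Compound 3 is expected at 250 nM, with an estimated range of 70 nM to 800 nM.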

Compound 3, concentration for 50% growth inhibition: 233 nM
Compound 3: middle estimate off by 1.1-fold (0.03 log units), on the high side; measured number inside the range.
By their numbers in this assay, from the lowest: compounds 2 and 3 (each within the scatter of the next); then compound 1.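

In this assay the swap of pyridin-4-yl for 6-fluoropyridin-2-yl gives a 1.7-fold higher number from compound 2 to compound 3 (0.24 log units; within the scatter) and so, on this saturated chain carbon bound to an aromatic nitrogen, the two rings cannot be told apart. Measured against the phenyl group, the new ring shows a 4.3-fold lower number from compound 1 to compound 3 (0.64 log units; beyond the scatter) and this means that the lower number seen earlier is not confined to pyridin-4-yl: two different pyridine rings now each beat phenyl by more than the scatter. Nothing measured here offers an explanation for these numbers.

As far as these compounds go, compound 3 differs from compound 2 both in carrying a fluorine and in how the ring is attached, so the contribution of each remains open, and a plain pyridin-2-yl group would help to separate them. Also open, from the compounds shown here alone, is whether an aromatic ring is needed on this chain carbon at all, or whether a morpholine or another simple amine on a longer chain could take its place.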